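The source may hold more compounds than are shown below. What is called first, only, known or untested is meant among the compounds shown, and "the series" means these compounds.

Measured compounds:
- Compound 1 `CCCC(=O)C1=C(C)NC(=O)NC1c1ccco1`: 1%
- Compound 2 `CCC(CC)OC(=O)C1=C(C)NC(=O)NC1c1ccco1`: 1%

In an assay on membranes from HeLa cells for displacement of a labelled ligand from adenosine receptor A3 (Homo sapiens), read by scintillation counting, with a stated time of 180 min, tested at 1 uM (on this read-out lower numbers stand for less inhibition and higher numbers for more inhibition at the one concentration tested (going by the name of the read-out)), compound 1 gives 1% and compound 2 gives 1%. Among the compounds with values here, the single measured step, no change at the digits printed from compound 1 to compound 2 (within the scatter), is the only one on record, so compound 2 stands level with compound 1 and both sit at the bottom of the read-out.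

Compound 3 `CC1=C(C(=O)OCC2CCC2)C(c2ccco2)NC(=O)N1` is the next compound to be tested. Its difference from compound 2 is cyclobutylmethyl in place of pentan-3-yl on an oxygen next to a carbonyl group.

Within the data shown here, the one measured step, from compound 1 to compound 2, replaced the group on the carbonyl carbon and produced no change. The move to compound 3 again exchanges only the group on the oxygen next to a carbonyl group, keeping the rest of the shared core intact, so no step beyond the scatter is expected in this assay.

Compound 3 is therefore estimated at 2%, with a range from -5% to 12%. This estimate means an expected step of a number 1 percentage points higher from compound 2 to compound 3 (within the scatter), within the scatter.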

Compound 3, a percentage reported as inhibition, at one concentration (the size of the read-out at that concentration, not a potency): 1%
For compound 3 the middle estimate is 1 percentage points above the measured one; measured number inside the range.
By their numbers in this assay, from the lowest: compounds 1, 2 and 3 (each within the scatter of the next).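

In this assay, putting cyclobutylmethyl in place of pentan-3-yl on an oxygen next to a carbonyl group brings in a four-membered ring of carbon only, with the same count of heavy atoms, and gives no change at the digits printed from compound 2 to compound 3 (within the scatter). Putting cyclobutylmethoxy in place of propyl on a carbonyl carbon gives no change at the digits printed from compound 1 to compound 3 (within the scatter). So a ring at this position, like the open-chain pentan-3-yl, leaves the read-out at the bottom at the one concentration tested, and nothing available explains this result.

As far as these compounds go, what stays open is whether any group at this position can lift the read-out, for example an amine or a benzyl group. From the compounds shown here alone, with all three compounds at the bottom, the effect of a change elsewhere on the shared core also remains unknown.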